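Compound 4: an aryl exchange on the shared core

This account rests on a few compounds, and the source may have more. Where it says the series, first, only, none or still open, it means among the compounds named here.

In an ADME assay on HepG2 cells (Homo sapiens) for cytotoxicity, read by MTT assay, with a stated time of 72 h (a higher number here means that more compound is tolerated, a lower number that less compound is tolerated), compound 3 (`O=[N+]([O-])c1c(CS(=O)(=O)c2ccccc2)nc2c(-c3ccc(F)cc3)cc(Cl)cn12`) gives > 15600 nM, which is a limit of the assay and not a number. Compound 1 (`CCN(CC)c1ccc(-c2cc(Cl)cn3c([N+](=O)[O-])c(CS(=O)(=O)c4ccccc4)nc23)cc1`) gives > 15600 nM, also a limit. Compound 2 (`O=[N+]([O-])c1c(CS(=O)(=O)c2ccccc2)nc2c(-c3ccccc3CO)cc(Cl)cn12`) gives a number, 88000 nM. The three compounds thus show (the limit of > 15600 nM in this assay, at which 2 of the 3 values shown sit).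

Compound 4 (`O=[N+]([O-])c1c(CS(=O)(=O)c2ccccc2)nc2c(-c3ccccc3C(F)(F)F)cc(Cl)cn12`) carries 2-(trifluoromethyl)phenyl in place of 4-fluorophenyl on an aromatic carbon.

Within the data shown here, two measured steps bear on this change: a step that the limit leaves unreadable from compound 2 to compound 3 and a step that the two limits leave unreadable from compound 1 to compound 3. Neither has a readable size, so neither supports a direction for the new step. Among the measured compounds shown here, the expectation therefore rests on the numbers themselves, with compound 2 at 88000 nM as the only measured number on the shared core. No change beyond the scatter is expected, and the expected step is a step that the limit leaves unreadable from compound 3 to compound 4. Another limit is a likely outcome. Compound 4 is estimated at 25000 nM, with an expected range from 10000 nM to 80000 nM.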

Compound 4, half-maximal cytotoxic concentration: 22700 nM
For compound 4 the middle estimate is 1.1-fold (0.04 log units) above the measured one; the measured number falls inside the stated range.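

In this assay, the aryl group on the shared core now has its first readable step, a 3.9-fold lower number from compound 2 to compound 4 (0.59 log units; beyond the scatter), with trifluoromethyl in place of hydroxymethyl. Of these two groups, then, 2-(hydroxymethyl)phenyl goes with more compound tolerated and 2-(trifluoromethyl)phenyl with less, though the step is modest and rests on this single pair. The steps to compound 4 from compound 3 and from compound 1 cannot be read, because each starts from a limit of the assay and not from a number: the limit of > 15600 nM in this assay, at which 2 of the 4 values shown sit.

The compounds shown leave open how 4-fluorophenyl or 4-(diethylamino)phenyl compares with 2-(trifluoromethyl)phenyl in numbers. They also leave open how the step would run with an aminomethyl group or a carboxylic acid in place of hydroxymethyl on the same phenyl.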